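The source may report more compounds than this note shows. Statements on the series, on what has been measured and on what is new or still open speak of the compounds shown alone.

Compound 1, `O=[N+]([O-])c1cc(Sc2nnnn2Cc2ccccc2)cc([N+](=O)[O-])c1`, gives 127000 nM.
Compound 2, `Cc1ccc(Cn2nnc(-c3cc([N+](=O)[O-])cc([N+](=O)[O-])c3)n2)cc1`, gives 200000 nM.
Compound 3, `O=[N+]([O-])c1cc(-c2nnn(Cc3cccc(Br)c3)n2)cc([N+](=O)[O-])c1`, gives 29000 nM.

These numbers come from an ADME assay on CHO-K1 cells (Cricetulus griseus) for cytotoxicity, read by MTT assay, with a stated time of 24 h; a lower number here means a stronger inhibitor, a higher number a weaker inhibitor. Compound 3 has the lowest number of the three: compound 1 sits above it and compound 2 further above it, both gaps beyond the usual scatter. For the measured compounds named here, only one measured step separates two compounds that differ in a single place, namely a 6.9-fold lower number from compound 2 to compound 3 (0.84 log units; beyond the scatter), in which a 3-bromophenyl took the place of a 4-methylphenyl on the saturated chain carbon bound to an aromatic nitrogen.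

Compound 4, `COc1cccc(Cn2nnc(-c3cc([N+](=O)[O-])cc([N+](=O)[O-])c3)n2)c1`, is not yet measured. It differs from compound 3 in one place: methoxy in place of bromo on an aromatic carbon. Going by the values given here, the measured step bears on this only at a distance, since it changed both the group and where it sits on the ring; no measured pair swaps one group for another at the same spot. Still, compound 2 carrying a 4-methylphenyl gives 200000 nM and compound 1 carrying a plain benzyl gives 127000 nM, while only compound 3, the one with the bromo, sits low. Removing the bromo is therefore expected to move the number back up, and compound 4 is expected to show a modest rise, a 2.8-fold higher number from compound 3 to compound 4 (0.44 log units; beyond the scatter). The estimate for compound 4 is 80000 nM, with a range from 25000 nM to 250000 nM.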

Compound 4, half-maximal inhibitory concentration: > 100000 nM
Compound 4 gave a limit, no number; the forecaster's own chance of this, stated with the estimate: 10%; at least 1.2-fold (0.09 log units) between middle value and limit.
By their numbers in this assay, from the lowest: compound 3; then compounds 1 and 2 (each within the scatter of the next).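

In this assay compound 4 gives > 100000 nM, which is a limit of the assay and not a number. Even so, this result supplies the first comparison in which one group replaces another at the same spot, on an aromatic carbon meta to a large group, and it can be read as an at least 3.4-fold higher number from compound 3 to compound 4 (0.53 log units; beyond the scatter), so the identity of the group at this carbon matters on its own, whereas the earlier step changed both the group and its place on the ring. The step between compound 2 and compound 4 cannot be read, so the 3-methoxyphenyl and 4-methylphenyl compounds cannot be placed in order, and the limit marks where the comparison stops: the limit of > 100000 nM in this assay, at which 1 of the 4 values shown sits.

The compounds shown leave open whether the lower number of compound 3 belongs to bromo in particular or would also appear with chloro, an amine or a carboxylic acid on the same carbon. They also leave open whether a plain hydrogen at this carbon, on the core of compound 3, would give a number closer to that of compound 3 or to the limit of compound 4.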